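Chloro in Place of Methoxy on the Benzyl Arm

The compounds below may be only part of what the source reports. "The series", "measured", "known", "first", "only" and "open" are said of these compounds alone.

Measured compounds:
compound 1 `COc1ccc(Cc2nnc(NC(=O)/C(C#N)=C/c3ccccc3OS(=O)(=O)c3ccc([N+](=O)[O-])cc3)s2)cc1`: 70%
compound 2 `COc1ccc(Cc2nnc(NC(=O)/C(C#N)=C/c3ccccc3OS(=O)(=O)c3ccc(F)cc3)s2)cc1`: 80%

In a functional assay on RS4-11 cells (Homo sapiens) for inhibition, read by CCK-8 assay, with a stated time of 48 h, tested at 20 uM (on this read-out higher numbers stand for more inhibition of growth at the one concentration tested and lower numbers for less inhibition of growth), compound 1 gives 70%, and compound 2 gives 80%. Going by the values given here, the one step between them, a number 10 percentage points higher from compound 1 to compound 2 (within the scatter), came with fluoro in place of nitro on an aromatic carbon and lies within the scatter, so the two numbers cannot be told apart. Compound 2 carries the higher of the two numbers shown, with compound 1 as its only neighbour and within the scatter of it.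

Compound 3 `N#C/C(=C\c1ccccc1OS(=O)(=O)c1ccc(F)cc1)C(=O)Nc1nnc(Cc2ccc(Cl)cc2)s1` is the next compound. It differs from compound 2 by chloro in place of methoxy on an aromatic carbon. Among the compounds with values here, the single measured step, from compound 1 to compound 2, touched a different aromatic carbon with a different pair of groups and was itself within the scatter, so no measured step bears directly on this change. Nothing in the two numbers points in either direction for this assay, and a step no larger than the scatter, a number 5 percentage points lower from compound 2 to compound 3 (within the scatter), is expected. Compound 3 is therefore estimated at 75%, in a range from 58% to 92%.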

Compound 3, percent growth inhibition at one concentration: 64%
Compound 3: middle estimate off by 11 percentage points, on the high side, within the range that was stated.
By their numbers in this assay, from the lowest: compounds 3, 1 and 2 (each within the scatter of the next, the first and the last beyond it).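

In this assay the 4-methoxybenzyl arm proves to be a position that can register a change: chloro in place of methoxy, para to a large group on the six-membered aromatic ring, came with a number 16 percentage points lower from compound 2 to compound 3 (beyond the scatter) while the rest of the structure stayed the same. This is the first step among the compounds shown that lies beyond the scatter, although it is modest, whereas the earlier step on a different aromatic carbon did not clear it. No measurement at hand accounts for the difference seen with this exchange.

With only methoxy and chloro shown on this carbon, the compounds leave open whether the lower number follows from the loss of methoxy or from the arrival of chloro. They also leave open where a compound carrying fluoro, hydroxy, methyl or an amine on the same carbon would fall relative to compound 2 and compound 3, and whether the difference between this pair would hold at concentrations other than the single one tested.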